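The compounds below may be only part of what the source reports. "The series", "measured", "known", "first", "only" and "open" are said of these compounds alone.

Series notes. Compound 1 `CCn1c(C(=O)NCCC(=O)OC)ccc1C(CC)(CC)c1ccc(OCS(=O)(=O)c2ccccc2)c(C)c1` serves as the reference point; in a functional assay on PC-3 cells (Homo sapiens) for antiproliferative activity, read by MTT assay, with a stated time of 24 h (on this read-out higher numbers stand for weaker inhibition and lower numbers for stronger inhibition), compound 1 gives 40400 nM, the highest of the three numbers recorded so far. Compound 2 `CCn1c(C(=O)N[C@H](CO)CCO)ccc1C(CC)(CC)c1ccc(OCS(=O)(=O)c2ccccc2)c(C)c1` gives 12100 nM in this assay, and compound 3 `CCn1c(C(=O)N[C@H](CO)CCCO)ccc1C(CC)(CC)c1ccc(OCS(=O)(=O)c2ccccc2)c(C)c1` gives 6810 nM. The measured steps are a 3.3-fold lower number from compound 1 to compound 2 (0.52 log units; beyond the scatter), a 5.9-fold lower number from compound 1 to compound 3 (0.77 log units; beyond the scatter) and a 1.8-fold lower number from compound 2 to compound 3 (0.25 log units; within the scatter).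

Compound 4 `CCn1c(C(=O)N[C@@H](CO)CCCO)ccc1C(CC)(CC)c1ccc(OCS(=O)(=O)c2ccccc2)c(C)c1` has not yet been measured. Relative to compound 1 the change is a group of 7 heavy atoms (5 carbon, 2 oxygen; no ring) in place of a group of 6 heavy atoms (4 carbon, 2 oxygen; no ring), on an amide-type nitrogen. The step bearing most directly on it is a 5.9-fold lower number from compound 1 to compound 3 (0.77 log units; beyond the scatter): the group entering compound 4 matches that entering compound 3 in every counted respect and differs only at the defined stereocentre. The step of a 3.3-fold lower number from compound 1 to compound 2 (0.52 log units; beyond the scatter) points the same way. For the measured compounds named here, no measured pair in this assay separates the two configurations at that stereocentre, so the expected step for compound 4 is taken close to that of compound 3, with wider bounds to cover the unknown effect of the configuration. The expectation for compound 4 in this assay is a 5.1-fold lower number from compound 1 to compound 4 (0.70 log units; beyond the scatter), an estimated value of 8000 nM with a range of 3500 nM to 20000 nM.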

Compound 4, half-maximal inhibitory concentration: 13400 nM
For compound 4 the middle estimate is 1.7-fold (0.22 log units) below the measured one, and the stated range covers the measured number.
By their numbers in this assay, from the lowest: compounds 3, 2 and 4 (each within the scatter of the next); then compound 1.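

In this assay, for the compounds shown here, the pair compound 3 and compound 4 gives the first reading of the two configurations at this stereocentre, a 2.0-fold higher number from compound 3 to compound 4 (0.29 log units; within the scatter), so S and R are not separated here, and the comparison isolates configuration alone: the fact that compounds 3 and 4 differ only in the configuration as drawn. The drop from the ester-bearing reference also holds for the R form, with a 3.0-fold lower number from compound 1 to compound 4 (0.48 log units; beyond the scatter), so replacing 2-(methoxycarbonyl)ethyl on the amide-type nitrogen lowers the number beyond the scatter in both configurations. With a 1.1-fold higher number from compound 2 to compound 4 (0.04 log units; within the scatter), the group of 6 heavy atoms and the R group of 7 heavy atoms are not separated either.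

From the compounds shown here alone, it remains open whether a single hydroxy group, a carboxylic acid or an amine in place of the two hydroxy groups would keep these lower numbers. Going by these compounds, it is also open whether a longer chain would separate the two configurations.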